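The source may hold more compounds than are shown below. What is called first, only, known or untested is meant among the compounds shown, and "the series" means these compounds.

Working notes on the series in an assay on isolated protein for inhibition of polyamine deacetylase HDAC10 (Homo sapiens), read by fluorescence, with a stated time of 17 h; on this read-out lower numbers stand for stronger inhibition and higher numbers for weaker inhibition. Of the compounds shown here, two have numbers so far. Compound 1 `Nc1cccc(-c2csc(NC(=O)CCCCCC(=O)Nc3ccccc3N)n2)c1` gives 2910 nM in this assay, which is the highest of the two numbers. Compound 2 `CC(C)(C)OC(=O)Nc1cccc(-c2csc(NC(=O)CCCCCC(=O)NO)n2)c1` gives 5.7 nM in this assay, a far lower number, and the gap between compound 1 and compound 2 lies well beyond the scatter. Compound 1 and compound 2 differ in more than one place, so the two values show only that the gap is wide; no single change can be read from them.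

Compound 3 `CC(=O)Nc1cccc(-c2csc(NC(=O)CCCCCC(=O)Nc3ccccc3N)n2)c1` is still to be measured. Relative to compound 1 the change is acetyl in place of hydrogen on a nitrogen on an aromatic ring, amino to acetamido. Within the data shown here, no pair of measured compounds in this assay differs by this change alone, so there is no measured step to lean on. The expectation is a step from compound 1 to compound 3 of a 1.5-fold lower number from compound 1 to compound 3 (0.16 log units; within the scatter), a modest move toward a lower number but not clearly beyond the scatter. Compound 3 is accordingly estimated at 2000 nM in this assay, with a range from 600 nM to 7000 nM.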

Compound 3, half-maximal inhibitory concentration: 3000 nM
For compound 3 the middle estimate is 1.5-fold (0.18 log units) below the measured one, and the stated range covers the measured number.
By their numbers in this assay, from the lowest: compound 2; then compounds 1 and 3 (each within the scatter of the next).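

In this assay, among these compounds, the step is a 1.0-fold higher number from compound 1 to compound 3 (0.01 log units; within the scatter), the first single change that can be read. At this place, on a nitrogen on an aromatic ring, amino to acetamido adds an acetyl of 3 heavy atoms and leaves the two numbers within the scatter of each other, with the rest of the structure the same. Within this pair, then, the free amino group and the acetamido group cannot be told apart on this read-out, which the wide gap between compound 1 and compound 2 could not show, as those two differ in more than one place. No measurement on hand bears on why the two numbers stay together.

As far as these compounds go, whether this holds only for acetyl stays open: a methanesulfonyl group on the same nitrogen, or a carboxylic acid in place of the amino group, could give a different picture. It is also open whether acetyl in place of hydrogen would give a step of similar size on a compound carrying the other chain end seen in compound 2, as no such pair is shown.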